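The source may report more compounds than this note shows. Statements on the series, on what has been measured and on what is new or still open speak of the compounds shown alone.

Measured compounds:
- compound 1 `CCNC(=O)Nc1c(OCCCn2cnc(-c3ccccc3)c2)cccc1N(C)C`: in an assay on aorta for inhibition of acyl-CoA:cholesterol acyltransferase (Oryctolagus cuniculus) (a lower number here means a stronger inhibitor, a higher number a weaker inhibitor), compound 1 gives > 10000 nM, which is a limit of the assay rather than a number (the limit of > 10000 nM in this assay, at which 1 of the 3 values shown sits).
- compound 2 `CCCCCNC(=O)Nc1c(OCCCn2cnc(-c3ccccc3)c2)cccc1N(C)C`: in this assay compound 2 gives 160 nM.
- compound 3 `CN(C)c1cccc(OCCCn2cnc(-c3ccccc3)c2)c1NC(=O)NC1CCCC1`: in this assay compound 3 gives 3530 nM.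

Compound 3 stands highest of the two numbers available; the nearest is compound 2, with a 22-fold higher number from compound 2 to compound 3 (1.34 log units; beyond the scatter). Compound 4 `CCCCCC(=O)Nc1c(OCCCn2cnc(-c3ccccc3)c2)cccc1N(C)C` differs from compound 3 by pentyl in place of cyclopentylamino on a carbonyl carbon, so the urea becomes an amide while a pentyl chain returns.

Going by the values given here, two measured steps bear on this. a 22-fold higher number from compound 2 to compound 3 (1.34 log units; beyond the scatter) shows the pentyl chain on the amide-type nitrogen well ahead of cyclopentyl, and an at least 62-fold lower number from compound 1 to compound 2 (1.79 log units; beyond the scatter) shows the chain length itself matters strongly. Among the compounds with values here, neither step tests the loss of the amide-type nitrogen, so that part of the change has no precedent here, and the expectation is tempered accordingly.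

A clearly lower number is therefore expected for compound 4, on the order of a 7.1-fold lower number from compound 3 to compound 4 (0.85 log units; beyond the scatter). The estimate for compound 4 in this assay is 500 nM, with a range from 80 nM to 4000 nM.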

Compound 4, half-maximal inhibitory concentration: 100 nM
Compound 4: the middle estimate sits 5.0-fold (0.70 log units) above what was measured; the measured number falls inside the stated range.
By their numbers in this assay, from the lowest: compounds 4 and 2 (each within the scatter of the next); then compound 3. At a limit, above all of these: compound 1.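

In this assay, the amide-type nitrogen of the urea is not required once the five-carbon chain is kept: pentyl in place of pentylamino on the carbonyl carbon gives a 1.6-fold lower number from compound 2 to compound 4 (0.20 log units; within the scatter), so the amide and the urea cannot be told apart here. Pentyl in place of cyclopentylamino gives a 35-fold lower number from compound 3 to compound 4 (1.55 log units; beyond the scatter), and with the nitrogen exchange alone lying within the scatter, this large step tracks the open chain against the ring rather than the loss of the nitrogen. Pentyl in place of ethylamino gives an at least 100-fold lower number from compound 1 to compound 4 (2.00 log units; beyond the scatter), a bound set by a limit of the assay and not a measured size: the limit of > 10000 nM in this assay, at which 1 of the 4 values shown sits.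

Going by these compounds, how a shorter butyl or a longer heptyl chain on the carbonyl carbon would compare remains open. So does whether a branched chain, or a terminal amine or carboxylic acid on the pentyl chain, would hold the value.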